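A few compounds are considered here, and "the series" means these few. Any claim that something is new, unique, unknown or untested is made for them only; others in the source may bear on it.

Measured so far in a physicochemical assay for lipophilicity, using the shake flask method, measured as octanol-water partition, at pH 7.4; on this read-out lower numbers stand for lower lipophilicity and higher numbers for higher lipophilicity:

- compound 1 `CC(=O)N[C@@H]1CCC[C@H](C(=O)Nc2cc(-c3cnn(C)c3C)c(Cl)cn2)C1` gives 2.6
- compound 2 `CC(=O)N[C@@H]1CCC[C@H](C(=O)Nc2cc(-c3cnc4n3CCCC4)c(Cl)cn2)C1` gives 2.7
- compound 3 `CC(=O)N[C@@H]1CCC[C@H](C(=O)Nc2cc(-c3cnn4c3CCC4)c(Cl)cn2)C1` gives 2.9

Compound 3 lies within the scatter of the other two. The steps to it are a number 0.30 log units higher from compound 1 to compound 3 (within the scatter) and a number 0.20 log units higher from compound 2 to compound 3 (within the scatter), and the remaining step is a number 0.10 log units higher from compound 1 to compound 2 (within the scatter).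

Compound 4 `CC(=O)N[C@@H]1CCC[C@H](C(=O)Nc2cc(-c3cnn4c3NCCC4)c(Cl)cn2)C1` has not yet been measured. It differs from compound 3 in one place, on an aromatic carbon ortho to a chloro group: a group of 9 heavy atoms (6 carbon, 3 nitrogen; one five-membered aromatic ring with 2 hetero atoms, one six-membered non-aromatic ring with 2 hetero atoms) in place of a group of 8 heavy atoms (6 carbon, 2 nitrogen; one five-membered non-aromatic ring with 1 hetero atom, one five-membered aromatic ring with 2 hetero atoms), on an aromatic carbon. A six-membered non-aromatic ring with 2 hetero atoms thus takes the place of a five-membered non-aromatic ring with 1 hetero atom, and only the entering group has a hydrogen-bond donor.

Among the compounds with values here, the nearest precedent for the ring change is a number 0.20 log units higher from compound 2 to compound 3 (within the scatter), which stays within the scatter. Within the data shown here, no measured compound has a hydrogen-bond donor in this group, so the data do not test that part of the change directly. The expected change in this assay is therefore a modest fall, estimated as a number 0.40 log units lower from compound 3 to compound 4 (beyond the scatter) with little certainty about its size. The estimate for compound 4 is 2.5, with an expected range from 2.1 to 2.9.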

Compound 4, distribution coefficient: 2.4
Compound 4: the middle estimate sits 0.10 log units above what was measured; the measured number falls inside the stated range.
By their numbers in this assay, from the lowest: compounds 4, 1, 2 and 3 (each within the scatter of the next, the first and the last beyond it).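

In this assay, this position on the ring carrying the chloro group now shows its first step beyond the scatter: a number 0.50 log units lower from compound 3 to compound 4 (beyond the scatter). The result depends on the comparison, since a number 0.30 log units lower from compound 2 to compound 4 (within the scatter) and a number 0.20 log units lower from compound 1 to compound 4 (within the scatter); the entering group, with its six-membered non-aromatic ring with 2 hetero atoms and 1 hydrogen-bond donor, therefore separates clearly only from the group in compound 3, and compound 2, which also has a six-membered non-aromatic ring, stays within the scatter of compound 4. No measurement shown here accounts for the step from compound 3 to compound 4.

The ring size and the hydrogen-bond donor change together in these compounds, so their separate contributions to the step cannot be told apart. On these data alone, it also remains open how this assay would read with an ether oxygen or a methylated amine in place of the ring amine in compound 4, either of which would keep the six-membered ring while changing the atom that carries the amine hydrogen.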